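From compound 2 to compound 3: a methylcarbamoyl swap

The source may hold more compounds than are shown below. What is called first, only, known or untested is meant among the compounds shown, and "the series" means these compounds.

Measured in an ADME assay on microsomes from liver (Rattus norvegicus, strain Sprague-Dawley) for pharmacokinetics, read by LC-MS, using NADPH, with a stated time of 45 min, tested at 1 uM (on this read-out lower numbers stand for slow clearance and higher numbers for fast clearance), so far:
- Compound 1 `COc1cc(OCc2ccnc(N)n2)cc2sc(N[C@H]3CCCC[C@@H]3O)nc12` gives 20 mL/min/kg
- Compound 2 `CNC(=O)Nc1nccc(COc2cc(OC)c3nc(N[C@H]4CCCC[C@@H]4O)sc3c2)n1` gives 19 mL/min/kg

Compound 2, at 19 mL/min/kg, stands level with compound 1, since the two values lie within the scatter of each other. Compound 3 `COc1cc(OCc2ccnc(Nc3ccn(C)n3)n2)cc2sc(N[C@H]3CCCC[C@@H]3O)nc12` has yet to be measured in this assay. It keeps the shared core, and 1-methyl-1H-pyrazol-3-yl takes the place of methylcarbamoyl on a nitrogen on an aromatic ring (1-methyl-1H-pyrazol-3-yl in place of methylcarbamoyl on a nitrogen on an aromatic ring).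

Going by the values given here, one measured step bears on this nitrogen. The change a 1.1-fold lower number from compound 1 to compound 2 (0.02 log units; within the scatter) put methylcarbamoyl in place of hydrogen and stayed within the scatter. Among the compounds with values here, that step gives a first sign that this position tolerates change in this read-out, but no measured compound carries a ring on this nitrogen, so the evidence is thin. No shift beyond the scatter is therefore expected, and the range is kept wide. The expected change is a 1.3-fold higher number from compound 2 to compound 3 (0.10 log units; within the scatter), which would lie within the scatter. For compound 3 the estimated clearance is 24 mL/min/kg, with an expected range from 11 mL/min/kg to 50 mL/min/kg.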

Compound 3, clearance: 46.2 mL/min/kg
The estimate for compound 3 lay 1.9-fold (0.28 log units) below the measured number; measured number inside the range.
By their numbers in this assay, from the lowest: compounds 2 and 1 (each within the scatter of the next); then compound 3.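

In this assay, this nitrogen on an aromatic ring proved not to be indifferent to what it carries. The earlier pair had stayed within the scatter, but 1-methyl-1H-pyrazol-3-yl raised clearance both when it replaced methylcarbamoyl (a 2.4-fold higher number from compound 2 to compound 3 (0.39 log units; beyond the scatter)) and when it replaced hydrogen (a 2.3-fold higher number from compound 1 to compound 3 (0.36 log units; beyond the scatter)), so both steps go the same way and lie beyond the scatter, while hydrogen and methylcarbamoyl remain level with each other. Nothing available explains what in the 1-methyl-1H-pyrazol-3-yl group lies behind this rise.

The compounds shown leave open whether the rise belongs to this particular five-membered aromatic ring, to its methyl group, or to any ring on this nitrogen, a question that a phenyl ring or a pyrazole without the methyl group would address. They also leave open whether a small acyl group such as acetyl, or a plain methyl group, would stay level with compound 1 and compound 2 on this read-out.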